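The source may hold more compounds than are shown below. What is called first, only, known or untested is meant among the compounds shown, and "the series" means these compounds.

Three compounds share one core and differ only in the group on a single aromatic carbon. Compound 1 `CCCCOC(=O)NS(=O)(=O)c1ccc(CCC)cc1-c1ccc(Cn2c(C3CCCC3)nc3ccccc32)cc1` carries cyclopentyl, compound 2 `CCCCOC(=O)NS(=O)(=O)c1ccc(CCC)cc1-c1ccc(Cn2c(C3CC3)nc3ccccc32)cc1` cyclopropyl and compound 3 `CCCCOC(=O)NS(=O)(=O)c1ccc(CCC)cc1-c1ccc(Cn2c(CC(C)C)nc3ccccc32)cc1` isobutyl. In an assay on membranes from HEK293 cells for displacement of a labelled ligand from Type-2 angiotensin II receptor (Homo sapiens), read by radioligand binding (a higher number here means a weaker inhibitor, a lower number a stronger inhibitor), compound 1 gives 35 nM, compound 2 gives 31 nM and compound 3 gives 19 nM, the lowest of the three numbers. The steps were a 1.1-fold lower number from compound 1 to compound 2 (0.05 log units; within the scatter), a 1.8-fold lower number from compound 1 to compound 3 (0.27 log units; within the scatter) and a 1.6-fold lower number from compound 2 to compound 3 (0.21 log units; within the scatter). Compound 4 `CCCCOC(=O)NS(=O)(=O)c1ccc(CCC)cc1-c1ccc(Cn2c(-c3nccs3)nc3ccccc32)cc1` brings (1,3-thiazol-2-yl in place of isobutyl on an aromatic carbon). Going by these compounds, the measured steps bear on this only loosely: each exchanged one carbon-only group for another, and none moved the number beyond the scatter, while a ring with two hetero atoms is untested here. A small step is therefore expected, a 1.3-fold higher number from compound 3 to compound 4 (0.12 log units; within the scatter). Compound 4 is estimated at 25 nM, with a range from 8 nM to 80 nM.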

Compound 4, inhibition constant: 5.1 nM
Compound 4: middle estimate off by 4.9-fold (0.69 log units), on the high side; the measured number lies below the stated range.
By their numbers in this assay, from the lowest: compound 4; then compounds 3, 2 and 1 (each within the scatter of the next).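

Going by these compounds alone, replacing the carbon-only groups with 1,3-thiazol-2-yl on this carbon gives the first steps beyond the scatter in this assay (a 3.7-fold lower number from compound 3 to compound 4 (0.57 log units; beyond the scatter); a 6.1-fold lower number from compound 2 to compound 4 (0.78 log units; beyond the scatter); a 6.9-fold lower number from compound 1 to compound 4 (0.84 log units; beyond the scatter)). Cyclopentyl, cyclopropyl and isobutyl could not be told apart, so this position can respond to the group it carries, at least when that group is a five-membered aromatic ring with hetero atoms. No measurement shown here explains the gain. Phenyl, a ring with no hetero atoms, and 1,3-oxazol-2-yl, with oxygen in place of sulfur, remain open: they could show whether the aromatic ring alone or its particular atoms go with the lower number.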